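Carbonyl substituent swap from compound 3 to compound 4

This account rests on a few compounds, and the source may have more. Where it says the series, first, only, none or still open, it means among the compounds named here.

Measured in a functional assay on blood (Homo sapiens), with a stated time of 60 min, in the presence of a further agent that is not named here; on this read-out higher numbers stand for an effect only at larger amounts of compound and lower numbers for an effect already at smaller amounts:
compound 1 `O=C(OCc1ccccc1)C1(S(=O)(=O)c2ccc(Oc3ccc(OC(F)(F)F)cc3)cc2)CCC2(CCNCC2)C1`: > 15000 nM (a limit)
compound 2 `O=C(Nc1ccccn1)C1(S(=O)(=O)c2ccc(Oc3ccc(OC(F)(F)F)cc3)cc2)CCC2(CCNCC2)C1`: > 15000 nM (a limit)
compound 3 `O=C1CN(C(=O)C2(S(=O)(=O)c3ccc(Oc4ccc(OC(F)(F)F)cc4)cc3)CCC3(CCNCC3)C2)CCN1`: 7500 nM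

Going by the values given here, compound 3 holds the only actual number in this set, 7500 nM. For compound 1 and compound 2 the read-out is only a limit, (the limit of > 15000 nM in this assay, at which 2 of the 3 values shown sit).

Compound 4 `Nc1ccc(F)cc1NC(=O)C1(S(=O)(=O)c2ccc(Oc3ccc(OC(F)(F)F)cc3)cc2)CCC2(CCNCC2)C1` carries (2-amino-5-fluorophenyl)amino in place of 3-oxopiperazin-1-yl on a carbonyl carbon. Among the compounds with values here, no measured step makes this exact exchange. The closest is an at least 2.0-fold lower number from compound 2 to compound 3 (0.30 log units; that floor lies within the scatter), which replaces (pyridin-2-yl)amino with the 3-oxopiperazin-1-yl group that compound 4 lacks. an at least 2.0-fold lower number from compound 1 to compound 3 (0.30 log units; that floor lies within the scatter) arrives at the same group from benzyloxy. Going by these compounds, both are floors, so the true sizes remain open, and a step that the two limits leave unreadable from compound 1 to compound 2 adds nothing readable.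

The nearest match to the entering group is compound 2, whose > 15000 nM is a limit. Exchanging 3-oxopiperazin-1-yl for an aromatic ring on the amino group is therefore expected to move the number upward in this assay, and the expected step is a 1.6-fold higher number from compound 3 to compound 4 (0.20 log units; within the scatter). For compound 4 the estimated value is 12000 nM, with an expected range of 4000 nM to 30000 nM.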

Compound 4, half-maximal effective concentration: > 15000 nM
Compound 4: no number, only a limit; the forecaster's own chance of this, stated with the estimate: 50%; middle value at least 1.2-fold (0.09 log units) away from the limit.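

In this assay compound 4 gives > 15000 nM, which is a limit and not a number. On this carbonyl carbon, (2-amino-5-fluorophenyl)amino in place of 3-oxopiperazin-1-yl gives an at least 2.0-fold higher number from compound 3 to compound 4 (0.30 log units; that floor lies within the scatter), so the change is known only as a floor, while the steps to compound 4 from compound 1 and compound 2 cannot be read, since both ends of each are limits. The substituted aromatic ring on the amino group thus joins the pyridin-2-yl and benzyloxy entries at the limit, leaving compound 3, the only entry here without an aromatic ring in this group, as the only compound with an actual number: the limit of > 15000 nM in this assay, at which 3 of the 4 values shown sit.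

Going by these compounds, the true size of the step to compound 4 remains open, as does whether compound 1, compound 2 and compound 4 differ from one another beyond the limit. Also open, on these data alone, is how a piperazin-1-yl group lacking the ring carbonyl, a morpholin-4-yl group or a free carboxylic acid at this carbonyl carbon would read in this assay, and so whether the ring carbonyl of compound 3 matters at all.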